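Oxazolidinone side-chain exchanges: sulfonamide to amide

A few compounds are considered here, and "the series" means these few. Any claim that something is new, unique, unknown or untested is made for them only; others in the source may bear on it.

Compound 3 `CS(=O)(=O)NC[C@H]1CN(c2ccc(-n3cc(-c4ccccn4)cn3)c(F)c2)C(=O)O1` gives 1.38 in a physicochemical assay for lipophilicity, read by HPLC, measured as octanol-water partition (a lower number here means a more polar compound, a higher number a more lipophilic compound), the lowest of the three numbers measured. Compound 1 `CN(CCC#N)C[C@H]1CN(c2ccc(-n3cc(-c4ccccn4)cn3)c(F)c2)C(=O)O1` gives 1.9 and compound 2 `O=C1CSC(=O)N1C[C@H]1CN(c2ccc(-n3cc(-c4ccccn4)cn3)c(F)c2)C(=O)O1` gives 2.18; the steps of a number 0.52 log units lower from compound 1 to compound 3 (beyond the scatter) and a number 0.80 log units lower from compound 2 to compound 3 (beyond the scatter) place compound 3 beyond the scatter below both, whereas a number 0.28 log units higher from compound 1 to compound 2 (within the scatter) stays inside it. Compound 4 `CNC(=O)[C@H]1CN(c2ccc(-n3cc(-c4ccccn4)cn3)c(F)c2)C(=O)O1` carries the change (methylcarbamoyl in place of (methanesulfonamido)methyl on a saturated ring carbon). Going by the values given here, no measured step exchanges the methylcarbamoyl group, so the three steps bear on it only by showing that the methanesulfonamido compound sits at the low end of this small set. In the absence of a comparable exchange, the step expected is a number 0.07 log units higher from compound 3 to compound 4 (within the scatter), within the scatter. Compound 4 is therefore estimated at 1.45, with a range from 1 to 1.9.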

Compound 4, partition coefficient: 1.39
For compound 4 the middle estimate is 0.06 log units above the measured one; low and high end bracket the measured number.
By their numbers in this assay, from the lowest: compounds 3 and 4 (each within the scatter of the next); then compounds 1 and 2 (each within the scatter of the next).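

In this assay, the methylcarbamoyl group on the saturated ring carbon and the (methanesulfonamido)methyl group are not told apart (a number 0.01 log units higher from compound 3 to compound 4 (within the scatter)). The low end of the set therefore holds two different side chains, and compound 4 also lies beyond the scatter below the other two (a number 0.79 log units lower from compound 2 to compound 4 (beyond the scatter); a number 0.51 log units lower from compound 1 to compound 4 (beyond the scatter)). No measured evidence bearing on this result is available.

From the compounds shown here alone, whether this match extends to a carboxylic acid, a primary amine or a longer amide chain at the same ring carbon remains open.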